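The compounds below may be only part of what the source reports. "The series", "measured", "known", "first", "only" and "open" are said of these compounds alone.

The series shares the core of compound 1 `CCC(=O)N1CC2CC(C1)N2`, with an ethyl on the carbonyl carbon. In an assay on SH-EP1 cells for agonist activity at Neuronal acetylcholine receptor; alpha4/beta2 (Homo sapiens), read by FLIPR and calcium flux (on this read-out higher numbers stand for an effect only at larger amounts of compound and lower numbers for an effect already at smaller amounts), compound 1 gives 490 nM. For the measured compounds named here, compound 2 `O=C([C@@H]1C[C@H]1F)N1CC2CC(C1)N2` has a 2-fluorocyclopropyl on that carbonyl carbon instead; in this assay compound 2 gives 120 nM, the lowest of the two numbers so far, with compound 1 as its only neighbour. Going by the values given here, the one step measured, a 4.1-fold lower number from compound 1 to compound 2 (0.61 log units; beyond the scatter), is modest in size. Compound 3 `C[C@H]1C[C@@H]1C(=O)N1CC2CC(C1)N2` is not yet measured. The change is 2-methylcyclopropyl in place of 2-fluorocyclopropyl on a carbonyl carbon. Among the compounds with values here, no measured step swaps a fluorine for a methyl on this ring, so the only guidance is the step of a 4.1-fold lower number from compound 1 to compound 2 (0.61 log units; beyond the scatter), which shows the cyclopropyl amide itself is tolerated. A step of about a 1.7-fold higher number from compound 2 to compound 3 (0.22 log units; within the scatter) is therefore expected, with no firm direction. Compound 3 is estimated at 200 nM, with a range from 60 nM to 650 nM.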

Compound 3, half-maximal effective concentration: 9100 nM
Compound 3: middle estimate off by 46-fold (1.66 log units), on the low side; measured number above the stated range.
By their numbers in this assay, from the lowest: compound 2; then compound 1; then compound 3.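

In this assay the 2-methylcyclopropyl in place of 2-fluorocyclopropyl gives a 76-fold higher number from compound 2 to compound 3 (1.88 log units; beyond the scatter) even though both groups hold the same count of heavy atoms and the same three-membered ring, so this place on the carbonyl carbon responds sharply to what the ring carries. Against the plain ethyl, the 2-methylcyclopropyl gives a 19-fold higher number from compound 1 to compound 3 (1.27 log units; beyond the scatter) and the lower number of compound 2 therefore does not follow from the cyclopropyl ring alone, which corrects the earlier reading that this amide is simply tolerated. Nothing available explains the gap between the fluorine and the methyl on this ring.

Still open, from the compounds shown here alone, is where an unsubstituted cyclopropyl, a chlorine or a hydroxyl on the ring would fall relative to compound 2 and compound 3. Also open, going by these compounds, are the effect of the other stereoisomers of these rings and of a longer chain in place of the ethyl of compound 1.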